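A few compounds are considered here, and "the series" means these few. Any claim that something is new, unique, unknown or untested is made for them only; others in the source may bear on it.

Notes on a small series built on one shared core. Compound 1 `CC(C)=CCC/C(C)=C/CC1Cc2c(O)cc(=O)n(CCCO)c2CC1(C)C`, compound 2 `CC(C)=CCC1Cc2c(OCc3ccccc3)cc(=O)n(CCCO)c2CC1(C)C` and compound 3 `COc1ccc(C(=O)NCCCOc2cc(=O)n(CCCO)c3c2CC(CC=C(C)C)C(C)(C)C3)cc1` have been tested in a functional assay on PANC-1 cells (Homo sapiens) for inhibition, read by MTT assay, with a stated time of 24 h, tested at 10 uM; a lower number here means less inhibition, a higher number more inhibition at the concentration tested (going by the name of the read-out). In this assay compound 1 gives 28.7%, compound 2 gives -0.3% and compound 3 gives 55.5%. Compound 2 stands lowest of the three; its gap to compound 1 and its gap to compound 3 both lie beyond the usual scatter, so on these numbers compound 2 gives the lowest inhibition in this assay of the set. Compound 4 `CC(C)=CCC1Cc2c(OC(=O)Nc3cccc(F)c3)cc(=O)n(CCCO)c2CC1(C)C` has not yet been measured. It differs from compound 2 in one place: (3-fluorophenyl)carbamoyl in place of benzyl on an oxygen on an aromatic ring. Among the measured compounds shown here, no step between measured compounds covers this exact change, so the expectation rests on the series as a whole. Compound 3, which also carries a larger group on that oxygen, reaches the highest number, and this is the only hint that a bigger substituent there may go with a higher number in this assay. The expected step is a number 20.3 percentage points higher from compound 2 to compound 4 (beyond the scatter), upward, but with wide uncertainty. Compound 4 is estimated at 20% in this assay, with a range from -5% to 45%.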

Compound 4, a percentage reported as inhibition, at one concentration (the size of the read-out at that concentration, not a potency): 66.1%
For compound 4 the middle estimate is 46.1 percentage points below the measured one, outside the stated range (above it).
By their numbers in this assay, from the lowest: compound 2; then compound 1; then compound 3; then compound 4.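

In this assay, among the compounds shown here, (3-fluorophenyl)carbamoyl in place of benzyl on an oxygen on an aromatic ring gives a number 66.4 percentage points higher from compound 2 to compound 4 (beyond the scatter), the first one-place step. The low number of compound 2 is therefore not set by the shared core alone: with the rest of the structure unchanged, the group on this oxygen can carry a large change in the read-out. The entering group brings a hydrogen-bond donor and a hydrogen-bond acceptor that benzyl lacks, but nothing available bears on why the step is this large.

The compounds shown do not separate the carbamoyl link from the fluorine, so the result for phenylcarbamoyl without fluorine, or for a plain acetyl on that oxygen, remains open. Also open, as far as these compounds go, is whether the step holds with the longer chain of compound 1 on the core.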